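The source may report more compounds than this note shows. Statements on the series, on what has been measured and on what is new or still open speak of the compounds shown alone.

In an ADME assay on MT4 cells (Homo sapiens) for cytotoxicity (on this read-out higher numbers stand for lower toxicity in this test and lower numbers for higher toxicity in this test), compound 1 `COC(=O)N[C@H](C(=O)NN(CCC[C@@](O)(Cc1ccccc1)C(=O)N[C@H]1c2ccccc2C[C@H]1O)CC(C)C)C(C)(C)C` gives > 10000 nM as a limit of the assay and not a number. Compound 2 `COC(=O)N[C@H](C(=O)NN(CCC[C@@](O)(Cc1ccccc1)C(=O)N[C@H]1c2ccccc2C[C@H]1O)Cc1ccc(-n2ccnc2)cc1)C(C)(C)C` gives > 10000 nM as a limit too. Among the measured compounds shown here, compound 2 thus stands with the only other measured compound, and the record so far is the limit of > 10000 nM in this assay, at which 2 of the 2 values shown sit, and nothing more. For the measured compounds named here, the single measured step is a step that the two limits leave unreadable from compound 1 to compound 2 and so offers no size to carry forward.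

Compound 3 `COC(=O)N[C@H](C(=O)NN(CCC[C@@](O)(Cc1ccccc1)C(=O)N[C@H]1c2ccccc2C[C@H]1O)Cc1ccc(-c2noc(C)n2)cc1)C(C)(C)C` keeps the rest of compound 2 and has 5-methyl-1,2,4-oxadiazol-3-yl in place of 1H-imidazol-1-yl on an aromatic carbon of a six-membered aromatic ring of carbon only, para to a large group. The counted difference is 5-methyl-1,2,4-oxadiazol-3-yl in place of 1H-imidazol-1-yl on an aromatic carbon and it is small beside the groups already tried at this part of the molecule.

Going by the values given here, the only guide is that compound 2 and compound 1 both sit at one limit. No step beyond the scatter is expected in this assay and no direction can be named, so the estimated change is a step that the limit leaves unreadable from compound 2 to compound 3 at most in name. For compound 3 the expected value is an estimated 15000 nM within a range of 8000 nM to 40000 nM and it will most likely be reported as a limit again.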

Compound 3, half-maximal cytotoxic concentration: > 10000 nM
Compound 3 gave a limit, no number (the forecaster's own chance of this, stated with the estimate: 85%); the middle value lies beyond the limit too.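

In this assay compound 3 gives > 10000 nM, a limit of the assay and not a number. Among the compounds shown here, compound 1 and compound 2 also sit at limits, so no step among the three compounds can be read. The compounds shown leave open how far apart these three lie in this assay, and whether any group tried here would give a measured number.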